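Swapping a dichlorophenoxy arm for a methoxyphenylthio arm

The source may report more compounds than this note shows. Statements on the series, on what has been measured and on what is new or still open speak of the compounds shown alone.

Compound 1 `Nc1cc(N)c2nc(-c3ccccc3)c(Oc3ccc(Cl)c(Cl)c3)nc2c1` gives 33900 nM in a functional assay on NCI-H522 cells (Homo sapiens) for inhibition, read by sulforhodamine B assay, with a stated time of 48 h; a higher number here means a weaker inhibitor of growth, a lower number a stronger inhibitor of growth.
Compound 2 `CCOC(=O)[C@H](CCC(=O)O)NC(=O)c1ccc(CNc2nc3cc(N)cc(N)c3nc2-c2ccccc2)cc1` reaches only a limit, < 100000 nM, in this assay.
Compound 3 `COc1cc(CNc2nc3cc(N)cc(N)c3nc2-c2ccccc2)cc(OC)c1OC` likewise reaches only a limit, < 50200 nM, in this assay.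

All three compounds share one core and differ only in the group attached to it on an aromatic carbon of the shared core. Compound 1 is the only one of the three with an actual number in this assay, and that number points to a weak inhibitor of growth. The other two entries are not numbers but limits: the limit of < 100000 nM in this assay, at which 1 of the 3 values shown sits, and (the limit of < 50200 nM in this assay, at which 1 of the 3 values shown sits). Within the data shown here, no pair of measured compounds differing in one place gives a step whose size could be carried over.

The unmeasured compound 4 `COc1ccc(Sc2nc3cc(N)cc(N)c3nc2-c2ccccc2)cc1` differs from compound 1 by a single exchange: (4-methoxyphenyl)sulfanyl in place of 3,4-dichlorophenoxy on an aromatic carbon. Among the measured compounds shown here, with no measured step of comparable kind to lean on, the most defensible expectation is that the change stays within the usual scatter of repeated measurements, so the step is estimated as a 1.0-fold higher number from compound 1 to compound 4 (0.01 log units; within the scatter). On that basis compound 4 is expected to give about 35000 nM in this assay, with a plausible range from 12000 nM to 100000 nM, and a fair chance that only a limit is reported.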

Compound 4, concentration for total growth inhibition: < 100000 nM
Compound 4: no number, only a limit (the forecaster's own chance of this, stated with the estimate: 30%); the middle value is on the limit's open side.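

In this assay compound 4 gives < 100000 nM, which is a limit and not a number. The step from compound 1 to compound 4 therefore cannot be read. The compounds shown leave open how far, and in which direction, (4-methoxyphenyl)sulfanyl in place of 3,4-dichlorophenoxy shifts growth inhibition on the shared core.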